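The source may report more compounds than this note shows. Statements on the series, on what has been measured and on what is new or still open speak of the compounds shown alone.

Within the data shown here, in an in vivo ADME assay on the whole organism (plasma, strain Sprague-Dawley) for pharmacokinetics, with Rattus norvegicus as the target (on this read-out lower numbers stand for slow clearance and higher numbers for fast clearance), only two compounds have numbers so far. Compound 1 (`CN1CCCC1c1ccc(N2CC[C@H](NS(=O)(=O)/C=C/c3ccc(Cl)s3)C2=O)c(F)c1`) gives 11 mL/min/kg as its value, and compound 2 (`O=C1[C@@H](NS(=O)(=O)/C=C/c2ccc(Cl)s2)CCN1c1ccc(C2CCCN2)cc1F`) gives 2.8 mL/min/kg as the lower of the two. Among the measured compounds shown here, the one measured step is a 3.9-fold lower number from compound 1 to compound 2 (0.59 log units; beyond the scatter) and it is a change of hydrogen in place of methyl on an amine nitrogen in a ring.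

For the measured compounds named here, compound 3 (`O=C1[C@@H](NS(=O)(=O)c2ccc3c(Cl)c[nH]c3c2)CCN1c1ccc(C2CCCN2)cc1F`) keeps the rest of compound 2 but has 3-chloro-1H-indol-6-yl in place of 2-(5-chlorothiophen-2-yl)ethenyl on a sulfonyl sulfur as its single change. Going by the values given here, no measured step touches that group, and the data show no direction for this swap. The step from compound 1 serves only as a rough yardstick of size. Compound 2 already holds the lower of just two numbers, which makes a small rise the more likely expectation, and a large move in either direction cannot be ruled out. The expected change is a 1.6-fold higher number from compound 2 to compound 3 (0.21 log units; within the scatter) and it remains an estimate. For compound 3 the estimated clearance is 4.5 mL/min/kg with an expected range from 1.8 mL/min/kg to 12 mL/min/kg as the likely span.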

Compound 3, clearance: 1.3 mL/min/kg
For compound 3 the middle estimate is 3.5-fold (0.54 log units) above the measured one, outside the stated range (below it).
By their numbers in this assay, from the lowest: compound 3; then compound 2; then compound 1.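

Among these compounds, this is the first measured look at the group on the sulfonyl sulfur, as the earlier step changed only the amine nitrogen in a ring. In this assay, replacing 2-(5-chlorothiophen-2-yl)ethenyl with 3-chloro-1H-indol-6-yl gives a 2.2-fold lower number from compound 2 to compound 3 (0.33 log units; beyond the scatter), so this place can take a different group with two aromatic rings, one of them carrying a hydrogen-bond donor, and the number still falls to the lowest of the three. The swap alters several things at once, including the ring count, the double bond, the sulfur and the donor, and no measured information is available to separate them or to explain the fall.

The compounds shown leave open whether the chlorine matters, which a 1H-indol-6-yl group without it would test, and whether a simple phenyl group on the sulfonyl sulfur would give a similarly low number. From the compounds shown here alone, it is also open whether the step seen at the ring amine, a 3.9-fold lower number from compound 1 to compound 2 (0.59 log units; beyond the scatter), would hold with 3-chloro-1H-indol-6-yl on the sulfonyl sulfur, which a methyl on the amine nitrogen of compound 3 would show.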